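Trifluoromethoxy for Methyl on a Series Sitting at the Limit

This account rests on a few compounds, and the source may have more. Where it says the series, first, only, none or still open, it means among the compounds named here.

Compound 1 `Cc1nnsc1CO/N=C/c1c(C)nn(C)c1Oc1ccc(OC(F)(F)F)cc1`, compound 2 `CCc1nnsc1CO/N=C/c1c(C)nn(C)c1Oc1ccccc1Cl` and compound 3 `CCc1nnsc1CO/N=C/c1c(C)nn(C)c1Oc1ccc(C)cc1` share one core and differ only in the aryl ether. In a functional assay on Huh-7 cells (Homo sapiens) for inhibition, read by MTT assay, with a stated time of 48 h (a higher number here means a weaker inhibitor, a lower number a stronger inhibitor), compound 1 gives only a limit, > 50000 nM. In this assay compound 2 likewise gives a limit, > 50000 nM. Compound 3 also gives a limit, > 50000 nM. Compound 3 thus sits with the other two at the limit of > 50000 nM in this assay, at which 3 of the 3 values shown sit. Going by the values given here, the one step between measured compounds, a step that the two limits leave unreadable from compound 2 to compound 3, has no readable size, both of its ends being limits. Compound 4 `CCc1nnsc1CO/N=C/c1c(C)nn(C)c1Oc1ccc(OC(F)(F)F)cc1` differs from compound 3 by trifluoromethoxy in place of methyl on an aromatic carbon. Among the compounds with values here, no measured step bears directly on this change. Compound 1 carries the same trifluoromethoxy group on its aryl ether and shows only a limit in this assay, so compound 4 is expected to remain at the limit as well. The step from compound 3 to compound 4 is expected to be a step that the limit leaves unreadable from compound 3 to compound 4, not beyond the scatter. Compound 4 is estimated at 70000 nM, within 25000 nM to 250000 nM.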

Compound 4, half-maximal inhibitory concentration: > 50000 nM
Compound 4 ended at the assay's limit; the forecaster's own chance of this, stated with the estimate: 85%; the middle value lies beyond the limit too.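

Neither the step from compound 3 to compound 4 nor the step from compound 1 to compound 4 can be read, as both ends of each are limits: the limit of > 50000 nM in this assay, at which 4 of the 4 values shown sit.

The compounds shown leave open what size, if any, the changes in the aryl ether or the chain on the shared core have in this assay.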